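The compounds below may be only part of what the source reports. "The series", "measured", "known", "first", "only" and "open" are said of these compounds alone.

Going by the values given here, in an ADME assay on HepG2 cells (Homo sapiens) for cytotoxicity, read by MTT assay, with a stated time of 48 h (a higher number here means a weaker inhibitor, a lower number a stronger inhibitor), none of the three compounds measured so far gives a number. Compound 1 `O=S(=O)(c1ccc(-c2ccc3ncnc(Nc4ccc(OCc5cccc(F)c5)c(Cl)c4)c3c2)cc1)N1CCCC1` gives only a limit, > 15000 nM. Compound 2 `CS(=O)(=O)c1ccc(-c2ccc3ncnc(Nc4ccc(OCc5cccc(F)c5)c(Cl)c4)c3c2)cc1` also gives only a limit, > 15000 nM. Compound 3 `O=S(=O)(c1ccc(-c2ccc3ncnc(Nc4ccccc4)c3c2)cc1)N1CCOCC1` likewise stands at a limit, > 3000 nM. Compound 4 `COc1ccc(Nc2ncnc3ccc(-c4ccc(S(=O)(=O)N5CCOCC5)cc4)cc23)cc1Cl` differs from it as follows: 3-chloro-4-methoxyphenyl in place of phenyl on a nitrogen on an aromatic ring. In short, 3-chloro-4-methoxyphenyl stands in place of phenyl on a nitrogen on an aromatic ring. Among the compounds with values here, the only measured step, a step that the two limits leave unreadable from compound 1 to compound 2, concerns methyl in place of pyrrolidin-1-yl on a sulfonyl sulfur, so it offers no size to carry over. No step beyond the scatter and no direction can therefore be firmly expected, and the expected change is only loosely set at a step that the limit leaves unreadable from compound 3 to compound 4. For compound 4 the estimated value in this assay is 8000 nM, with an expected range of 2500 nM to 30000 nM.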

Compound 4, half-maximal inhibitory concentration: > 15000 nM
Compound 4 was reported as a limit; the forecaster's own chance of this, stated with the estimate: 65%; middle value at least 1.8-fold (0.27 log units) from the limit.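

In this assay compound 4 gives only a limit, > 15000 nM. Compound 3 also gives only a limit, > 3000 nM, so no step can be read between compound 3 and compound 4. The compounds shown leave open whether 3-chloro-4-methoxyphenyl in place of phenyl changes the value at all.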